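Capping the Chain Amine with Acetyl: Expected Tolerability

The compounds below may be only part of what the source reports. "The series", "measured", "known", "first", "only" and "open" are said of these compounds alone.

Measured compounds:
Compound 1, `NCCCCNc1cc(N2CCc3ccccc3C2)nc2ccccc12`, gives 7400 nM in an ADME assay on HEp-2 cells (Homo sapiens) for cytotoxicity, read by CCK-8 assay, with a stated time of 5 days; a lower number here means that less compound is tolerated, a higher number that more compound is tolerated.
Compound 2, `NCCNc1cc(N2CCCc3ccccc3C2)nc2ccc(Cl)cc12`, reaches only the limit of this assay, > 3200 nM.
Compound 3, `Cc1ccc2nc(N3CCCc4ccc(F)cc4C3)cc(NCCN)c2c1`, likewise reaches only the limit, > 3200 nM.

Compound 3 therefore stands at the limit of > 3200 nM in this assay, at which 2 of the 3 values shown sit, and no number beyond that limit is known for it. Compound 4, `CC(=O)NCCNc1cc(N2CCCc3ccc(F)cc3C2)nc2ccc(C)cc12`, carries one change relative to compound 3: acetyl in place of hydrogen on an amine nitrogen. Going by the values given here, no pair of measured compounds differs in exactly this way, so no measured step guides the expectation. Since a limit is all that compound 3 shows, the step from compound 3 to compound 4 is expected to be small, a step that the limit leaves unreadable from compound 3 to compound 4, with no shift beyond the scatter. Compound 4 is estimated at 8000 nM, with a range from 3200 nM to 20000 nM.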

Compound 4, half-maximal cytotoxic concentration: 66000 nM
Compound 4: the middle estimate sits 8.3-fold (0.92 log units) below what was measured; measured number outside the range, above it.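

The step from compound 3 to compound 4 cannot be read, because compound 3 gives only a limit: the limit of > 3200 nM in this assay, at which 2 of the 4 values shown sit. Going by these compounds, how far acetyl in place of hydrogen on an amine nitrogen shifts tolerance remains open.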